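Notes on the methoxy-to-hydroxy step toward compound 3

The compounds below may be only part of what the source reports. "The series", "measured", "known", "first", "only" and "open" are said of these compounds alone.

Compound 1 `O=C(Nc1ccc(F)c(Cl)c1)c1ccc2cn[nH]c2c1` was assessed in an assay on cells for inhibition of Amine oxidase [flavin-containing] A (Homo sapiens); on this read-out lower numbers stand for stronger inhibition and higher numbers for weaker inhibition. In this assay compound 1 gives only a limit, > 10000 nM. Compound 2 `COc1ccc(NC(=O)c2ccc3cn[nH]c3c2)cc1Cl` likewise gives only a limit in this assay, > 10000 nM. Among the compounds with values here, the single measured step, a step that the two limits leave unreadable from compound 1 to compound 2, is therefore of unreadable size, since both values sit at the limit of > 10000 nM in this assay, at which 2 of the 2 values shown sit. Compound 2 thus stands at the limit of this assay, with no number of its own on this read-out.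

Compound 3 `O=C(Nc1ccc(O)c(Cl)c1)c1ccc2cn[nH]c2c1` differs from compound 2 by hydrogen in place of methyl on an oxygen on an aromatic ring. Within the data shown here, no measured step bears directly on this change, and the one step on record is unreadable, so no direction beyond the scatter can be expected; the most likely outcome is that compound 3 again returns only a limit. Compound 3 is expected at 15000 nM, with a range from 4000 nM to 60000 nM. The expected step, a step that the limit leaves unreadable from compound 2 to compound 3, is estimated to lie within the scatter.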

Compound 3, half-maximal inhibitory concentration: > 10000 nM
Compound 3: only a limit was reported; the forecaster's own chance of this, stated with the estimate: 75%; the middle value is on the limit's open side.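

No step can be read among compound 1, compound 2 and compound 3, because all three stand at one limit in this assay: the limit of > 10000 nM in this assay, at which 3 of the 3 values shown sit.

The compounds shown leave open how fluoro, methoxy and hydroxy compare on the shared core, and whether any of them reaches a measurable value in this assay.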